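The source may hold more compounds than are shown below. What is called first, only, known or untested is meant among the compounds shown, and "the series" means these compounds.

Three compounds built on a shared core have been examined in a functional assay on GC-1 cells (Mus musculus) for cytotoxicity, read by MTT assay, with a stated time of 72 h; on this read-out lower numbers stand for stronger inhibition and higher numbers for weaker inhibition. Compound 1 `NC(=O)c1sc(Nc2ccccc2)nc1N` gives > 60000 nM, which is a limit of the assay and not a number. Compound 2 `Nc1nc(NC2CCCCC2)sc1C(=O)c1cccnc1` has no usable result, and its entry reads "not determined" (no result reported). Going by the values given here, compound 3 `Nc1nc(Nc2ccc(S(N)(=O)=O)cc2)sc1C(=O)c1ccccc1[N+](=O)[O-]` gives 20000 nM, the only actual number available, so it has no measured neighbour to be ranked against.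

The next compound to be tested is compound 4 `COc1cccc(C(=O)c2sc(Nc3ccc(S(N)(=O)=O)cc3)nc2N)c1`, which differs from compound 3 at a single place. The change is 3-methoxyphenyl in place of 2-nitrophenyl on a carbonyl carbon. Among the compounds with values here, no two measured compounds differ at only one place, so the data give no direct measure of what a change of this kind does in this assay. The expectation therefore starts from compound 3 at 20000 nM, and no shift in either direction beyond the usual scatter is expected. The estimated change is a 1.3-fold higher number from compound 3 to compound 4 (0.10 log units; within the scatter), and this estimate carries wide uncertainty. For compound 4 the expected value is 25000 nM, with an estimated range from 8000 nM to 60000 nM.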

Compound 4, half-maximal inhibitory concentration: 9100 nM
For compound 4 the middle estimate is 2.7-fold (0.44 log units) above the measured one, and the stated range covers the measured number.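

In this assay, there is now a pair of compounds that differ in only one place, and placing 3-methoxyphenyl instead of 2-nitrophenyl on the carbonyl carbon gives a 2.2-fold lower number from compound 3 to compound 4 (0.34 log units; beyond the scatter). The group at this position can therefore shift the number on its own, although this single modest step gives no cause for the shift and cannot establish a general trend. Compound 1 offers no such numerical reading, since its entry is a limit and not a number: the limit of > 60000 nM in this assay, at which 1 of the 4 values shown sits.

This step swaps the group carried by the ring and its place in the same move, so it cannot separate the loss of the nitro group from the gain of the methoxy group, or either of these from the change of place. A plain phenyl ring on the same carbonyl carbon would give a common reference for both groups, while a ring carrying an amine or a carboxylic acid would show whether other kinds of group move the number in the same direction.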